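The compounds below may be only part of what the source reports. "The series", "measured", "known", "first", "only" and "open" are said of these compounds alone.

Measured so far: compound 1 `CC(C)(C)c1ccc(C(=O)N2CCC3(CC2)C(=O)N(CC(=O)NCCO)CN3c2ccccc2)cc1` with 1000 nM; compound 2 `O=C(CN1CN(c2ccccc2)C2(CCN(C(=O)c3ccc(C4CCCCC4)cc3)CC2)C1=O)NCCO` with 2000 nM; compound 3 `CC(C)(C)c1ccc(C(=O)N2CCC3(CC2)C(=O)N(CC(=O)NCCC(=O)O)CN3c2ccccc2)cc1` with 11400 nM.

In an assay on HEK293 cells for displacement of a labelled ligand from NPC1-like intracellular cholesterol transporter 1 (Homo sapiens) (on this read-out lower numbers stand for stronger inhibition and higher numbers for weaker inhibition), compound 2 holds the second highest of the three numbers; its nearest neighbour is compound 1 (a 2.0-fold higher number from compound 1 to compound 2 (0.30 log units; within the scatter)), its furthest compound 3. Compound 4 `CC(C)(C)OC(=O)NCNC(=O)CN1CN(c2ccccc2)C2(CCN(C(=O)c3ccc(C4CCCCC4)cc3)CC2)C1=O` differs from compound 2 on a saturated chain carbon bound to an amide-type nitrogen: (tert-butoxycarbonyl)amino in place of hydroxymethyl on a saturated chain carbon bound to an amide-type nitrogen. Among the measured compounds shown here, no measured step makes this same change. The closest guide is the step at that chain from compound 1 to compound 3, which gave an 11-fold higher number from compound 1 to compound 3 (1.06 log units; beyond the scatter), the hydroxy being replaced there too. Compound 4 is therefore expected to give a higher number than compound 2, estimated at 5000 nM (range 1500 nM to 20000 nM). The expected step is a 2.5-fold higher number from compound 2 to compound 4 (0.40 log units; beyond the scatter).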

Compound 4, half-maximal inhibitory concentration: 1700 nM
Beside the measured number, compound 4's estimate is 2.9-fold (0.47 log units) above it; measured number inside the range.
By their numbers in this assay, from the lowest: compounds 1, 4 and 2 (each within the scatter of the next); then compound 3.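

In this assay, (tert-butoxycarbonyl)amino, with 8 heavy atoms in place of the 2 of hydroxymethyl, gives a 1.2-fold lower number from compound 2 to compound 4 (0.07 log units; within the scatter), so this place on the saturated chain carbon bound to an amide-type nitrogen accepts a much larger group without a change beyond the scatter. The large step with carboxy, an 11-fold higher number from compound 1 to compound 3 (1.06 log units; beyond the scatter), therefore does not extend to every replacement of the hydroxy on this chain. Nothing available explains why the two replacements differ.

Still open, from the compounds shown here alone, is how a free amine at this place would read, and whether a longer chain ending in (tert-butoxycarbonyl)amino would also stay within the scatter of compound 2.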